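This account rests on a few compounds, and the source may have more. Where it says the series, first, only, none or still open, it means among the compounds named here.

Compound 2, `C=CC1=C(C(=O)Nc2ccccc2)C(c2ccc(F)cc2)OC1`: 46700 nM
Compound 1, `C=CC1=C(C(=O)Nc2ccc(OCC)cc2)C(c2ccc(OC)cc2)OC1`: > 100000 nM

Within the data shown here, compound 2, `C=CC1=C(C(=O)Nc2ccccc2)C(c2ccc(F)cc2)OC1`, is the only compound with an actual number in a functional assay on QGY7701 cells (Homo sapiens) for cytotoxicity, read by MTT assay, with a stated time of 24 h (on this read-out higher numbers stand for weaker inhibition and lower numbers for stronger inhibition), where compound 2 gives 46700 nM. For compound 1, `C=CC1=C(C(=O)Nc2ccc(OCC)cc2)C(c2ccc(OC)cc2)OC1`, the same this assay reports only a limit, > 100000 nM, and no number. Compound 3, `C=CC1=C(C(=O)Nc2ccc(OCC)cc2)C(c2ccc(F)cc2)OC1`, has not yet been measured. It differs from compound 2 by ethoxy in place of hydrogen on an aromatic carbon. Among the measured compounds shown here, no step between measured compounds that differ in a single place is available, so the size of this change cannot be read from a measured pair. For the measured compounds named here, compound 1 carries the same ethoxy group and sits at the limit of > 100000 nM in this assay, at which 1 of the 2 values shown sits, but it also differs from compound 3 elsewhere in the structure, so it shows only that one ethoxy-bearing analogue lies at the limit. Compound 3 is therefore expected to be no stronger than compound 2, with a 1.7-fold higher number from compound 2 to compound 3 (0.23 log units; within the scatter) as a step of modest size toward weaker inhibition, possibly ending at the limit. Compound 3 is estimated at 80000 nM, within a range from 30000 nM to 250000 nM.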

Compound 3, half-maximal inhibitory concentration: 61600 nM
For compound 3 the middle estimate is 1.3-fold (0.11 log units) above the measured one; the range from low to high includes it.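

In this assay, the effect of the ethoxy group alone can now be read from a measured pair: a 1.3-fold higher number from compound 2 to compound 3 (0.12 log units; within the scatter), so at this place, para to a large group, ethoxy in place of hydrogen gives a step no larger than the scatter and does not by itself carry compound 3 to the limit. The second single change, fluoro in place of methoxy on an aromatic carbon, gives an at least 1.6-fold lower number from compound 1 to compound 3 (0.21 log units; that floor lies within the scatter), which is only a floor for that step. Compound 1 remains a limit and not a number: the limit of > 100000 nM in this assay, at which 1 of the 3 values shown sits.

Still open, as far as these compounds go, is how an amine, a carboxylic acid or a longer chain such as butoxy would read in place of the ethoxy group. The compounds shown also leave open whether the ethoxy step keeps its size when methoxy replaces fluoro elsewhere in the shared core.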